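Cytotoxicity notes on compounds 1 to 3

The compounds below may be only part of what the source reports. "The series", "measured", "known", "first", "only" and "open" are said of these compounds alone.

Measured compounds:
- compound 1 `CCn1cc(C(=O)O)c(=O)c2cc(F)c(N3CCN(CNC(=O)c4cnccn4)CC3)cc21`: > 62.5 ug/mL in a functional assay on Vero cells (Chlorocebus sabaeus) for cytotoxicity, read by MTT assay; a higher number here means that more compound is tolerated, a lower number that less compound is tolerated
- compound 2 `O=C(NCN1CCN(c2cc3c(cc2F)c(=O)c(C(=O)O)cn3C2CC2)CC1)c1cnccn1`: > 62.5 ug/mL in this assay

Compound 1 gives only a limit in this assay, not a number. Compound 2 likewise gives only a limit in this assay. The step that the two limits leave unreadable from compound 1 to compound 2 therefore cannot be read, and nothing about the size of a change on this part of the core can be drawn from it. What the two values share is the limit of > 62.5 ug/mL in this assay, at which 2 of the 2 values shown sit.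

Compound 3 `CCn1cc(C(=O)O)c(=O)c2cc(F)c(N3CCN(CNC(=O)c4cnccn4)CC3)c(F)c21` differs from compound 1 by fluoro in place of hydrogen on an aromatic carbon. For the measured compounds named here, no measured step touches this position, so the only evidence that bears on compound 3 is that both measured compounds sit at the same limit. On that basis no shift beyond the scatter is expected from compound 1 to compound 3, and the most likely outcome is again a limit rather than a number. The step that the limit leaves unreadable from compound 1 to compound 3 is an estimate, not a measurement. For compound 3 the expected value is 70 ug/mL, within 35 ug/mL to 150 ug/mL, with a high chance that the assay again reports only a limit.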

Compound 3, half-maximal cytotoxic concentration: > 62.5 ug/mL
Compound 3: a limit, no number (the forecaster's own chance of this, stated with the estimate: 85%); the middle value lies beyond the limit too.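

In this assay compound 3 gives > 62.5 ug/mL, which is a limit and not a number. With compound 1 also at a limit, no step can be read between compound 1 and compound 3, and the reading is shared across the series: the limit of > 62.5 ug/mL in this assay, at which 3 of the 3 values shown sit.

Left open is where the actual half-maximal cytotoxic concentrations of compound 1, compound 2 and compound 3 lie, and whether either change on the core shifts them.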